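The source may hold more compounds than are shown below. What is called first, only, known or untested is meant among the compounds shown, and "the series" means these compounds.

Working notes on the series. Within the data shown here, in a functional assay on HL-60 cells (Homo sapiens) for antiproliferative activity, read by sulforhodamine B assay, with a stated time of 48 h (a lower number here means a stronger inhibitor of growth, a higher number a weaker inhibitor of growth), compound 1 (`O=C(/C=C/c1cccc(S(=O)(=O)c2ccc3ccccc3n2)c1)NO`) gives 290 nM, the lowest of the three numbers so far. Compound 2 (`COc1ccc2nc(S(=O)(=O)c3cccc(/C=C/C(=O)NO)c3)ccc2c1`) gives 720 nM and compound 3 (`O=C(/C=C/c1cccc(S(=O)(=O)c2ccc3cc(Cl)ccc3n2)c1)NO`) gives 1330 nM.

The next compound to be read is compound 4 (`O=C(/C=C/c1cccc(S(=O)(=O)c2ccc3cccc(F)c3n2)c1)NO`). Its change from compound 1 is fluoro in place of hydrogen on an aromatic carbon, on a six-membered aromatic ring of carbon only that is part of a fused or bridged system of two rings.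

Among the measured compounds shown here, no fluoro compound has been measured, so the nearest evidence is two other replacements of hydrogen on an aromatic carbon. Methoxy gives a 2.5-fold higher number from compound 1 to compound 2 (0.39 log units; beyond the scatter) and chloro gives a 4.6-fold higher number from compound 1 to compound 3 (0.66 log units; beyond the scatter), both modest. Chloro in place of methoxy gives a 1.8-fold higher number from compound 2 to compound 3 (0.27 log units; within the scatter). Neither replacement lowered the number, though both sit on a different carbon from the fluoro.

A small upward move is expected in this assay, estimated as a 1.9-fold higher number from compound 1 to compound 4 (0.28 log units; within the scatter). For compound 4 the expected value is 550 nM, with an estimated range of 220 nM to 1300 nM.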

Compound 4, concentration for 50% growth inhibition: 720 nM
For compound 4 the middle estimate is 1.3-fold (0.12 log units) below the measured one, and the stated range covers the measured number.
By their numbers in this assay, from the lowest: compound 1; then compounds 2, 4 and 3 (each within the scatter of the next).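

In this assay, even fluoro, a single heavy atom with no hydrogen-bond donors or acceptors, on an aromatic carbon ortho to a fused ring and meta to a fused ring, gives a 2.5-fold higher number from compound 1 to compound 4 (0.39 log units; beyond the scatter) and so a step beyond the scatter. This extends the pattern to a third replacement of hydrogen: compounds 2, 3 and 4 all give higher numbers than compound 1, and no compound shown goes against it. No available evidence bears on the reason for this rise.

The compounds shown leave open whether an amine or a carboxylic acid on this same carbon would also raise the number. They also do not separate the effect of the position from that of the group, since no single group appears on more than one carbon.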